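The source may report more compounds than this note shows. Statements on the series, on what has been measured and on what is new or still open speak of the compounds shown alone.

Measured in an in vivo ADME assay on the whole organism (strain Sprague-Dawley) for pharmacokinetics, with Rattus norvegicus as the target, at a dose of 1 mg/kg; a lower number here means that more of the compound stays in the plasma, a higher number that more of the compound sits outside the plasma:
Compound 1 `CC(C)(O)c1ccn2c(-c3ccc(F)c(-c4cccnc4)c3)cnc2n1`: 1 L/kg
Compound 2 `CC(C)(O)c1cnn2c(-c3ccc(F)c(-c4ncc(F)cc4F)c3)cnc2n1`: 2.2 L/kg

Of these two compounds, compound 2 has the higher number at 2.2 L/kg, and the gap to compound 1 at 1 L/kg lies beyond the usual scatter. These two compounds differ in more than one place, so their gap cannot be assigned to any single change.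

Compound 3 `CC(C)(O)c1cnn2c(-c3ccc(F)c(-c4ncccc4C#N)c3)cnc2n1` has 3-cyanopyridin-2-yl in place of the 3,5-difluoropyridin-2-yl of compound 2, on an aromatic carbon, ortho to a fluoro group and meta to a large group: 3-cyanopyridin-2-yl in place of 3,5-difluoropyridin-2-yl on an aromatic carbon. Among the measured compounds shown here, no pair of measured compounds shows a step at a single place, so the data give no direct size for this exchange. The ring count stays the same and the heavy-atom count of the group is unchanged, so only a modest shift in this assay is expected, downward if anything and within the scatter. The expected step is a 1.5-fold lower number from compound 2 to compound 3 (0.17 log units; within the scatter). The estimate for compound 3 is 1.5 L/kg, with an expected range from 0.7 L/kg to 3 L/kg.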

Compound 3, volume of distribution at steady state: 1.7 L/kg
Beside the measured number, compound 3's estimate is 1.1-fold (0.05 log units) below it; the measured number falls inside the stated range.
By their numbers in this assay, from the lowest: compounds 1, 3 and 2 (each within the scatter of the next, the first and the last beyond it).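

In this assay, among the compounds shown here, putting 3-cyanopyridin-2-yl in place of 3,5-difluoropyridin-2-yl gives a 1.3-fold lower number from compound 2 to compound 3 (0.11 log units; within the scatter), the first step in this set that can be read at a single place. It shows that on this aromatic carbon, ortho to a fluoro group and meta to a large group, this exchange between two pyridine-based groups of equal heavy-atom count does not separate the two compounds in this read-out, even though a nitrile enters and both fluorines leave. The data offer nothing that explains why the two groups read alike.

Compound 1 differs from compound 2 and compound 3 in more than one place, so the compounds shown do not assign its gap to compound 2 to any single change, nor do they show how much the core and the pyridine-based group each contribute. They also leave open whether a group of another kind on this aromatic carbon, such as an amine or a carboxylic acid, would produce a step beyond the scatter.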